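The source may report more compounds than this note shows. Statements on the series, on what has been measured and on what is new or still open speak of the compounds shown alone.

Series notes, shared core. Compound 1 `O=c1ccoc2cc(OCc3cn(Cc4ccccc4)nn3)ccc12` gives in a functional assay on QGY7701 cells (Homo sapiens) for cytotoxicity, read by MTT assay, with a stated time of 48 h (a lower number here means a stronger inhibitor, a higher number a weaker inhibitor), only a limit, > 100000 nM; the line the limit of > 100000 nM in this assay, at which 1 of the 3 values shown sits, marks it as such. Compound 2 `O=c1ccoc2cc(OCc3cn(Cc4cccc(Br)c4)nn3)ccc12` gives 17600 nM in this assay, and compound 3 `O=c1ccoc2cc(OCc3cn(Cc4ccc(Cl)cc4Cl)nn3)ccc12` gives 13300 nM, the lowest of the two numbers shown, with compound 2 nearest: a 1.3-fold lower number from compound 2 to compound 3 (0.12 log units; within the scatter). The steps of an at least 5.6-fold lower number from compound 1 to compound 2 (0.75 log units; beyond the scatter) and an at least 7.5-fold lower number from compound 1 to compound 3 (0.87 log units; beyond the scatter) mark the two halogenated benzyl groups as at least modestly stronger than the plain one.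

Compound 4 `O=c1ccoc2cc(OCc3cn(Cc4cccc(Cl)c4)nn3)ccc12` is next: 3-chlorophenyl in place of 2,4-dichlorophenyl on a saturated chain carbon bound to an aromatic nitrogen. It sits closest to compound 2, where the change a 1.3-fold lower number from compound 2 to compound 3 (0.12 log units; within the scatter) stayed within the scatter, so no step beyond the scatter is expected in this assay; the estimated step is a 1.2-fold higher number from compound 3 to compound 4 (0.08 log units; within the scatter). Compound 4 is expected at 16000 nM, range 7000 nM to 40000 nM.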

Compound 4, half-maximal inhibitory concentration: 28400 nM
Compound 4: the middle estimate sits 1.8-fold (0.25 log units) below what was measured; low and high end bracket the measured number.
By their numbers in this assay, from the lowest: compounds 3, 2 and 4 (each within the scatter of the next, the first and the last beyond it). At a limit, above all of these: compound 1.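

Within the halogenated benzyl groups on the saturated chain carbon bound to an aromatic nitrogen, 2,4-dichlorobenzyl to 3-chlorobenzyl gives the first step beyond the scatter in this assay: a 2.1-fold higher number from compound 3 to compound 4 (0.33 log units; beyond the scatter). Chloro in place of bromo stays within the scatter: a 1.6-fold higher number from compound 2 to compound 4 (0.21 log units; within the scatter). Chloro in place of hydrogen is readable only as a bound, with compound 1 at a limit, an at least 3.5-fold lower number from compound 1 to compound 4 (0.54 log units; beyond the scatter): the limit of > 100000 nM in this assay, at which 1 of the 4 values shown sits.

Open, from the compounds shown here alone, is whether any gain survives without a halogen, as with a benzyl group carrying a methoxy group or an amine.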